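Swapping a trifluoromethyl for a hydroxy on the amide aryl

This account rests on a few compounds, and the source may have more. Where it says the series, first, only, none or still open, it means among the compounds named here.

Of the compounds shown here, three sharing one core have been tested in a functional assay on the whole organism for inhibition, with Rattus norvegicus as the target, read by paw edema, with stated times of 30 min and 2 h, at a dose of 0.28 mmol/kg by the oral route; on this read-out higher numbers stand for more inhibition at the one dose given (going by the name of the read-out) and lower numbers for less inhibition. Compound 1 `COc1ccc(-n2nc(C(N)=O)nc2-c2cc(OC)c(OC)c(OC)c2)cc1` carries a simple amide and gives 59%. Compound 2 `COc1ccc(-n2nc(C(=O)Nc3cccc(F)c3)nc2-c2cc(OC)c(OC)c(OC)c2)cc1` carries a 3-fluorophenyl on the amide nitrogen and gives 67%. Compound 3 `COc1ccc(-n2nc(C(=O)Nc3ccc(C(F)(F)F)cc3)nc2-c2cc(OC)c(OC)c(OC)c2)cc1` carries a 4-(trifluoromethyl)phenyl there and gives 55%, the lowest of the three numbers. The step of a number 12 percentage points lower from compound 2 to compound 3 (beyond the scatter) is the only one beyond the scatter; the steps of a number 8 percentage points higher from compound 1 to compound 2 (within the scatter) and a number 4 percentage points lower from compound 1 to compound 3 (within the scatter) are not.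

The next compound, compound 4 `COc1ccc(-n2nc(C(=O)Nc3ccc(O)cc3)nc2-c2cc(OC)c(OC)c(OC)c2)cc1`, differs from compound 3 in one place: hydroxy in place of trifluoromethyl on an aromatic carbon. Among the compounds with values here, no measured pair shows a hydroxy entering, so the measured steps bear on this change only loosely. They show that changing the group on the amide nitrogen moved the read-out by modest amounts at most, with compound 3 sitting at the low end. A small step, if any, is expected here, more likely upward than downward. Compound 4 is therefore expected to give about 60%, within a range from 46% to 74%. This corresponds to an expected step of a number 5 percentage points higher from compound 3 to compound 4 (within the scatter).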

Compound 4, a percentage reported as inhibition, in the whole organism at one dose (the size of the read-out at that dose, not a potency): 35%
Compound 4: middle estimate off by 25 percentage points, on the high side; the measured number lies below the stated range.
By their numbers in this assay, from the lowest: compound 4; then compounds 3, 1 and 2 (each within the scatter of the next, the first and the last beyond it).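

Hydroxy in place of trifluoromethyl on this aromatic carbon brings a clear loss in this assay (a number 20 percentage points lower from compound 3 to compound 4 (beyond the scatter)), so a single group on the amide aryl can matter here. The earlier aryl amides stayed within the scatter of the simple amide, whereas this one does not (a number 24 percentage points lower from compound 1 to compound 4 (beyond the scatter)), which shows that an aryl on the amide nitrogen does not always preserve the read-out. The gap to the 3-fluorophenyl amide is wider still (a number 32 percentage points lower from compound 2 to compound 4 (beyond the scatter)), though no measurement shown here explains the drop.

As far as these compounds go, it remains open whether the loss is specific to hydroxy, or whether an amine or a carboxylic acid on the same aromatic carbon would also lower the number. With only one dose, the compounds also leave open how they would compare at other doses.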